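This account rests on a few compounds, and the source may have more. Where it says the series, first, only, none or still open, it means among the compounds named here.

For the measured compounds named here, compound 3 `CONc1nc(C#Cc2cccnc2)nc2c1ncn2[C@@H]1O[C@H](CO)[C@@H](O)[C@H]1O` gives 255 nM in an assay on CHO cells for displacement of a labelled ligand from adenosine receptor A1 (Homo sapiens) (on this read-out lower numbers stand for stronger inhibition and higher numbers for weaker inhibition), the lowest of the three numbers measured so far. Compound 2 `CONc1nc(C#Cc2ccccn2)nc2c1ncn2[C@@H]1O[C@H](CO)[C@@H](O)[C@H]1O` gives 437 nM, and the step of a 1.7-fold lower number from compound 2 to compound 3 (0.23 log units; within the scatter) is too small to count. Compound 1 `CCC(=O)[C@H]1O[C@@H](n2cnc3c(N)nc(C#Cc4ccccc4)nc32)[C@H](O)[C@@H]1O`, built on a different core, gives 3920 nM. Compound 4 `C#Cc1nc(NOC)c2ncn([C@@H]3O[C@H](CO)[C@@H](O)[C@H]3O)c2n1` differs from compound 3 by hydrogen in place of pyridin-3-yl on a triple-bonded carbon. Going by the values given here, no measured step removes an aromatic ring from the triple-bonded carbon, so none bears directly on this change; the one step seen there, swapping one pyridyl for another, stayed within the scatter. Removing the ring altogether is a larger change, and compound 4 is therefore expected to bind more weakly, a 5.9-fold higher number from compound 3 to compound 4 (0.77 log units; beyond the scatter). The estimate for compound 4 is 1500 nM, within 300 nM to 8000 nM.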

Compound 4, inhibition constant: 25 nM
Compound 4: middle estimate off by 60-fold (1.78 log units), on the high side, outside the stated range (below it).
By their numbers in this assay, from the lowest: compound 4; then compounds 3 and 2 (each within the scatter of the next); then compound 1.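

On the triple-bonded carbon, an aromatic ring is not required for binding in this assay: hydrogen in place of pyridin-3-yl gives a 10-fold lower number from compound 3 to compound 4 (1.01 log units; beyond the scatter) and hydrogen in place of pyridin-2-yl gives a 17-fold lower number from compound 2 to compound 4 (1.24 log units; beyond the scatter). Swapping one pyridyl for the other had stayed within the scatter, whereas removing either ring produces a large step towards stronger inhibition. Nothing available explains this gain. From the compounds shown here alone, it remains open what a methyl group or a longer alkyl chain would give on this carbon, and whether hydrogen would bring the same gain on the core of compound 1.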